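A few compounds are considered here, and "the series" means these few. Any claim that something is new, unique, unknown or untested is made for them only; others in the source may bear on it.

Of the compounds shown here, three sharing one core have been measured in an assay on brain for displacement of a labelled ligand from Adrenergic receptor alpha-1 (Rattus norvegicus); a higher number here means a weaker inhibitor, a lower number a stronger inhibitor. Compound 1 `CCOCCOC1CCN(c2nc(N)c3cc(OC)c(OC)cc3n2)CC1` gives 1.81 nM. Compound 2 `COc1cc2nc(N3CCC(OCCOc4ccccc4)CC3)nc(N)c2cc1OC` gives 0.48 nM. Compound 3 `COc1cc2nc(N3CCC(OCC(C)OC)CC3)nc(N)c2cc1OC` gives 1.41 nM, which places it second highest of the three numbers, close to compound 1 and furthest from compound 2. The step from compound 1 to compound 3 was a 1.3-fold lower number from compound 1 to compound 3 (0.11 log units; within the scatter); the step from compound 2 to compound 3 was a 2.9-fold higher number from compound 2 to compound 3 (0.47 log units; beyond the scatter). Compound 4 `COc1cc2nc(N3CCC(OCC(C)O)CC3)nc(N)c2cc1OC` is the unmeasured one, and its change from compound 3 is hydrogen in place of methyl on an oxygen on a saturated carbon. Going by the values given here, no measured step removes a methyl from this oxygen, so the direct bearing is limited. The nearby change from ethoxymethyl to 1-methoxyethyl, seen in a 1.3-fold lower number from compound 1 to compound 3 (0.11 log units; within the scatter), stayed within the scatter, whereas a phenyl group in this side chain shifted the number beyond it in a 3.8-fold lower number from compound 1 to compound 2 (0.58 log units; beyond the scatter). Compound 4 is therefore expected to give 2.2 nM, with a range from 0.9 nM to 5.5 nM. The expected step is a 1.6-fold higher number from compound 3 to compound 4 (0.19 log units; within the scatter).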

Compound 4, inhibition constant: 3.52 nM
Compound 4: middle estimate off by 1.6-fold (0.20 log units), on the low side, within the range that was stated.
By their numbers in this assay, from the lowest: compound 2; then compounds 3, 1 and 4 (each within the scatter of the next, the first and the last beyond it).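

In this assay, going by these compounds alone, this is the first direct reading of hydrogen in place of methyl on this oxygen: a 2.5-fold higher number from compound 3 to compound 4 (0.40 log units; beyond the scatter) shows that the change from 2-methoxypropyl to 2-hydroxypropyl has a modest effect, towards a weaker inhibitor. Compound 4 still cannot be told apart from the ethoxy side chain of compound 1, since a 1.9-fold higher number from compound 1 to compound 4 (0.29 log units; within the scatter) is a step that stays small, while a 7.3-fold higher number from compound 2 to compound 4 (0.87 log units; beyond the scatter) is a much wider gap from the phenoxy side chain. Nothing available here gives a reason for these shifts.

Still open, from the compounds shown here alone, is how an amine in place of the hydroxy, or a carboxylic acid at the end of the chain, would read. A longer chain ending in hydroxy is equally unsettled, as is whether a phenyl group would restore the lower number of compound 2 with a hydroxy present.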